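This account rests on a few compounds, and the source may have more. Where it says the series, first, only, none or still open, it means among the compounds named here.

Among the compounds with values here, in a functional assay on HT-1080 cells (Homo sapiens) for cytotoxicity, read by MTT assay, with a stated time of 72 h (a higher number here means a weaker inhibitor, a lower number a stronger inhibitor), compound 1 `COc1cccc(/C=C2\CCC/C(=C\c3cccc(Br)c3)C2=O)c1OC` gives 12200 nM and compound 2 `COc1cccc(/C=C2\CCC/C(=C\c3cccc(OC)c3OC)C2=O)c1` gives 9900 nM, so compound 2 stands level with the only other measured compound. Within the data shown here, the single measured step, a 1.2-fold lower number from compound 1 to compound 2 (0.09 log units; within the scatter), exchanges bromo for methoxy on an aromatic carbon. Compound 3 `COc1cccc(/C=C2\CCC/C(=C\c3cc(Cl)cc(Cl)c3)C2=O)c1OC` differs from compound 2 by 3,5-dichlorophenyl in place of 3-methoxyphenyl on a double-bonded chain carbon bound to a double-bonded ring carbon, with 3,5-dichlorophenyl in place of 3-methoxyphenyl on a double-bonded chain carbon bound to a double-bonded ring carbon. Among the measured compounds shown here, with only that one small step as a guide, no shift beyond the scatter is expected. The estimated 1.2-fold lower number from compound 2 to compound 3 (0.07 log units; within the scatter) reflects this. In this assay, compound 3 is estimated at 8500 nM, with an expected range of 3500 nM to 20000 nM.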

Compound 3, half-maximal inhibitory concentration: 6100 nM
The estimate for compound 3 lay 1.4-fold (0.14 log units) above the measured number; the range from low to high includes it.
By their numbers in this assay, from the lowest: compounds 3, 2 and 1 (each within the scatter of the next).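

In this assay, 3,5-dichlorophenyl on a double-bonded chain carbon bound to a double-bonded ring carbon gives a 1.6-fold lower number from compound 2 to compound 3 (0.21 log units; within the scatter) in place of 3-methoxyphenyl, and a 2.0-fold lower number from compound 1 to compound 3 (0.30 log units; within the scatter) in place of 3-bromophenyl. The earlier pair covered only an exchange of bromo for methoxy, whereas these steps show that a ring carrying two chlorine atoms also stays within the scatter at this place. Nothing measured here explains these numbers. From the compounds shown here alone, whether an amine or a carboxylic acid on this phenyl ring would move the number beyond the scatter remains open.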